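The source may report more compounds than this note shows. Statements on the series, on what has been measured and on what is new or still open speak of the compounds shown alone.

Compound 1 `COc1cc([N+](=O)[O-])ccc1NC(=O)c1cc(Cl)ccc1O` is the only one of the three measured compounds to give a number in a physicochemical assay for solubility (a higher number here means a more soluble compound, a lower number a less soluble compound), where compound 1 gives 9.2 ug/mL. Compound 2 `O=C(Nc1ccc(C(F)(F)F)cc1)c1cc(Cl)ccc1O` is built on a different core, and how the two cores differ is not broken down here. In this assay compound 2 reaches only a limit of the assay, < 1 ug/mL. Compound 3 `O=C(Nc1ccc(C(F)(F)F)cc1)c1cc(Br)ccc1O` differs from compound 2 by bromo in place of chloro on an aromatic carbon. In this assay compound 3 likewise returns a limit of the assay, < 1 ug/mL. The step that the two limits leave unreadable from compound 2 to compound 3 therefore cannot be sized, because the limit of < 1 ug/mL in this assay, at which 2 of the 3 values shown sit, is where both of its values rest. Among the compounds with values here, compound 4 `COc1cc([N+](=O)[O-])ccc1NC(=O)c1cc(Br)ccc1O`, which has not yet been measured, differs from compound 1 by bromo in place of chloro on an aromatic carbon; this is the same change as the one made from compound 2 to compound 3, and it occurs twice among the compounds here. Since the earlier step gives no readable size, the expectation for compound 4 rests mainly on compound 1 and its value 9.2 ug/mL, taken as the starting point for a change of one heavy atom for another. Compound 4 is expected to come out near 6 ug/mL, somewhere between 2.5 ug/mL and 14 ug/mL. The step from compound 1 to compound 4 is estimated as a 1.5-fold lower number from compound 1 to compound 4 (0.19 log units; within the scatter), which would leave compound 4 within the usual scatter of compound 1.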

Compound 4, solubility: 1.6 ug/mL
For compound 4 the middle estimate is 3.8-fold (0.57 log units) above the measured one, and the stated range ends above it.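

In this assay, bromo in place of chloro on an aromatic carbon, para to a hydroxy group, gives a 5.8-fold lower number from compound 1 to compound 4 (0.76 log units; beyond the scatter), so on the core of compound 1 this change has a readable size and direction. On the core of compound 2 the same change cannot be read, so the data neither support nor contradict the idea that the step carries over from one core to the other, and the two steps cannot be set side by side: the limit of < 1 ug/mL in this assay, at which 2 of the 4 values shown sit. The readable step therefore rests on a single pair, compound 1 and compound 4, and it shows what the change did on that one core, not what it does across the series.

The compounds shown leave open how other groups at the same aromatic carbon, such as fluoro, iodo, a methyl or an amine, would stand against chloro and bromo in this assay. They also leave open whether a group such as a carboxylic acid in place of the nitro group of compound 1 or the trifluoromethyl group of compound 2 would change the size of the step seen with bromo.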